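Replacing the Carbamoyl Arm with a Bromopyridyl Ether

The source may hold more compounds than are shown below. What is called first, only, known or untested is meant among the compounds shown, and "the series" means these compounds.

Compound 1 `COc1nc(C)c(Nc2nc(Cl)cn([C@H](CO)C3CC3)c2=O)cc1C`: 88 nM
Compound 2 `COc1nc(C)c(Nc2nc(Cl)cn([C@H](COC(=O)c3ccccn3)C3CC3)c2=O)cc1C`: 67 nM
Compound 3 `COc1ccc(NC(=O)OC[C@H](C2CC2)n2cc(Cl)nc(Nc3cc(C)c(OC)nc3C)c2=O)c(C)n1`: 9.2 nM

The three measured compounds share one core and differ only in what sits on the oxygen of the side chain. In an assay on frontal cortex for displacement of a labelled ligand from corticotropin-releasing factor receptor 1 (Rattus norvegicus), with a stated time of 2 h (a higher number here means a weaker inhibitor, a lower number a stronger inhibitor), compound 1 gives 88 nM, compound 2 gives 67 nM and compound 3 gives 9.2 nM. Compound 3 stands lowest of the three numbers: a 9.6-fold lower number from compound 1 to compound 3 (0.98 log units; beyond the scatter) and a 7.3-fold lower number from compound 2 to compound 3 (0.86 log units; beyond the scatter), both beyond the scatter. By contrast, a 1.3-fold lower number from compound 1 to compound 2 (0.12 log units; within the scatter).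

Compound 4 `COc1nc(C)c(Nc2nc(Cl)cn([C@H](COc3cc(Br)ccn3)C3CC3)c2=O)cc1C` is the next step from compound 3: 4-bromopyridin-2-yl in place of (6-methoxy-2-methylpyridin-3-yl)carbamoyl on an oxygen on a saturated carbon. For the measured compounds named here, two measured steps bear on it. The step from compound 1 to compound 3 shows what the carbamoyl arm contributed, and compound 4 gives that arm up. The step from compound 1 to compound 2 shows that a pyridine attached to that oxygen through a carbonyl changed little, and compound 4 carries a pyridine attached directly. He therefore expects compound 4 to move back toward compounds 1 and 2 in this assay, a step upward beyond the scatter, a 5.4-fold higher number from compound 3 to compound 4 (0.74 log units; beyond the scatter). His estimate for compound 4 in this assay is 50 nM, with a range from 15 nM to 160 nM.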

Compound 4, half-maximal inhibitory concentration: 1.5 nM
Compound 4: the middle estimate sits 33-fold (1.52 log units) above what was measured, outside the stated range (below it).
By their numbers in this assay, from the lowest: compound 4; then compound 3; then compounds 2 and 1 (each within the scatter of the next).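

In this assay, the carbamoyl arm proves unnecessary for a low number at this oxygen: with the 4-bromopyridin-2-yl group in its place, which has fewer heavy atoms and 0 hydrogen-bond donors against 1, the number falls further (a 6.1-fold lower number from compound 3 to compound 4 (0.79 log units; beyond the scatter)). The earlier compounds shown here showed a pyridine held through a carbonyl doing little, whereas this directly attached bromopyridine gives the largest steps (a 45-fold lower number from compound 2 to compound 4 (1.65 log units; beyond the scatter)) and (a 59-fold lower number from compound 1 to compound 4 (1.77 log units; beyond the scatter)), so a pyridine on this oxygen can matter a great deal, depending on how it is attached and substituted. Nothing in the data given accounts for these steps.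

The step from the (pyridin-2-yl)carbonyl group to the 4-bromopyridin-2-yl group removes the carbonyl and adds the bromine together, so the compounds shown cannot say how much of the gain belongs to either change. On these data alone, it also stays open how a pyridin-2-yl ether without the bromine, one with chlorine or a methyl group in its place, or a plain phenyl ether would compare at this oxygen.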